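A few compounds are considered here, and "the series" means these few. Any claim that something is new, unique, unknown or untested is made for them only; others in the source may bear on it.

Working notes on the series. Compound 1 `COc1ccc(OC(=O)c2cn(-c3ccccc3)nc2-c2cccnc2)cc1` and compound 2 `O=C(NCc1ccccc1)c1cn(-c2ccccc2)nc1-c1ccncc1` share a common core, and both have been run in a functional assay on HeLa cells (Homo sapiens) for cytotoxicity, read by MTT assay, with a stated time of 48 h; on this read-out lower numbers stand for stronger inhibition and higher numbers for weaker inhibition. In this assay compound 1 gives > 100000 nM, which is a limit of the assay and not a number. In this assay compound 2 gives > 100000 nM, again a limit rather than a measured number. Among the compounds with values here, compound 2 therefore stands exactly where the only other measured compound stands, and nothing in the figures separates the two; the whole of the evidence is the limit of > 100000 nM in this assay, at which 2 of the 2 values shown sit. Within the data shown here, no step between measured compounds can be computed. Compound 3 `COc1ccc(OC(=O)c2cn(-c3ccccc3)nc2-c2ccncc2)cc1` is not yet measured. It differs from compound 2 in one place, (4-methoxyphenoxy in place of benzylamino on a carbonyl carbon), bringing in the same 4-methoxyphenoxy group that compound 1 carries on its carbonyl carbon. Since compound 1 and compound 2 both sit at the limit of > 100000 nM in this assay, at which 2 of the 2 values shown sit, the step expected in this assay from compound 2 to compound 3 is a step that the limit leaves unreadable from compound 2 to compound 3, none beyond the scatter. Compound 3 is accordingly estimated at 150000 nM, in a range from 50000 nM to 500000 nM, and the most probable outcome is that this assay again returns only a limit.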

Compound 3, half-maximal inhibitory concentration: > 100000 nM
Compound 3 ended at the assay's limit; the forecaster's own chance of this, stated with the estimate: 85%; the middle value is on the limit's open side.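

No step can be read among compound 1, compound 2 and compound 3 in this assay, as each gives a limit and not a number: the limit of > 100000 nM in this assay, at which 3 of the 3 values shown sit. The compounds shown leave open whether any change on the shared core brings a measurable value in this assay, and how large either exchange's effect would be.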